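The source may hold more compounds than are shown below. What is called first, only, known or untested is meant among the compounds shown, and "the series" means these compounds.

Among the measured compounds shown here, compound 2 `O=C(Nc1ccc(S(=O)(=O)Nc2ccccc2)cc1)c1ccc(Cl)cc1F` is the one compound of this small set with a measured number; in a functional assay on HEK293 cells for agonist activity at probable G-protein coupled receptor 27 (Homo sapiens), read by a luciferase reporter and beta-arrestin recruitment, with a stated time of 10 min (on this read-out higher numbers stand for larger maximal responses and lower numbers for smaller maximal responses), compound 2 gives 57%. Two further compounds belong to the same series: compound 1 `O=C(Nc1ccc(Cl)cc1Cl)c1ccc(S(=O)(=O)Nc2ccccc2)cc1`, for which this assay reports "not determined" (no result reported), and compound 3 `O=S(=O)(Nc1ccccc1)c1ccc(NS(=O)(=O)c2ccc(Cl)cc2Cl)cc1`, for which this assay reports "not determined" (no result reported); for neither of them was a number obtained in this assay, so compound 2 stands alone as the only point of reference, with no comparison possible among measured values.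

Compound 4 `O=C(Nc1ccc(S(=O)(=O)Nc2ccccc2)cc1)c1ccc(Cl)cc1Cl` is still to be measured. It differs from compound 2 in one place: chloro in place of fluoro on an aromatic carbon. For the measured compounds named here, no step between two measured compounds is available to show how such a swap plays out here, so the expectation rests on the single value of compound 2 and on the small size of the change, which exchanges one halogen for another without touching donors, acceptors or charge. Compound 4 is expected to reach about 55% in this assay, within a range from 30% to 80%. The step of a number 2 percentage points lower from compound 2 to compound 4 (within the scatter) is thus estimated to stay within the usual scatter, in no clear direction.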

Compound 4, largest response reached (Emax), in percent of the reference or control that the assay uses: 100%
Estimate against measurement, compound 4: 45 percentage points below; measured number above the stated range.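

In this assay, changing 4-chloro-2-fluorophenyl to 2,4-dichlorophenyl gives a number 43 percentage points higher from compound 2 to compound 4 (beyond the scatter), so this aromatic carbon, ortho to a large group, does not treat the two halogens as interchangeable. The change swaps one heavy atom for one heavy atom and alters no count of hydrogen-bond donors, hydrogen-bond acceptors or net charge, yet that single exchange is enough to move the maximal response well beyond the usual scatter. Nothing available here gives a measured reason for the step.

On these data alone, it remains open whether a bromo, methyl or methoxy group on this same carbon would match chloro, or whether a plain hydrogen there would fall short of both halogens. Compound 1 and compound 3 have no number in this assay, so their steps cannot be read.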